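Pentyl gives way to pyridin-4-yl on the amide nitrogen

A few compounds are considered here, and "the series" means these few. Any claim that something is new, unique, unknown or untested is made for them only; others in the source may bear on it.

In an ADME assay on MRC5 cells (Homo sapiens) for inhibition, with a stated time of 72 h (on this read-out lower numbers stand for an effect already at smaller amounts and higher numbers for an effect only at larger amounts of compound), compound 1 `COc1cccc(OC)c1C(=O)Nc1c[nH]nc1C(=O)NCc1ccccc1` gives 50000 nM. Compound 2 `COc1cccc(OC)c1C(=O)Nc1c[nH]nc1C(=O)NCC1CCCCC1` gives only a limit, > 50000 nM. Compound 3 `CCCCCNC(=O)c1n[nH]cc1NC(=O)c1c(OC)cccc1OC` also gives only a limit, > 50000 nM. Compound 3 thus stands at the limit of > 50000 nM in this assay, at which 2 of the 3 values shown sit.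

Compound 4 `COc1cccc(OC)c1C(=O)Nc1c[nH]nc1C(=O)Nc1ccncc1` differs from it as follows: pyridin-4-yl in place of pentyl on an amide-type nitrogen. This places pyridin-4-yl in place of pentyl on an amide-type nitrogen. The measured steps closest to this change, a number no lower from compound 1 to compound 3 (the limit leaves the size open) and a number no lower from compound 1 to compound 2 (the limit leaves the size open), have no readable size, and neither does a step that the two limits leave unreadable from compound 2 to compound 3. Among these compounds, only compound 1, which carries an aromatic phenyl ring, gives a number, 50000 nM. Little movement is therefore expected in this assay, with the expected step being an at least 1.1-fold lower number from compound 3 to compound 4 (0.04 log units; that floor lies within the scatter). Compound 4 is estimated at 45000 nM, with an expected range of 15000 nM to 50000 nM.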

Compound 4, half-maximal effective concentration: > 50000 nM
Compound 4: no number, only a limit; the forecaster's own chance of this, stated with the estimate: 60%; at least 1.1-fold (0.04 log units) between middle value and limit.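

In this assay compound 4 gives only a limit, > 50000 nM, so an aromatic ring on the amide-type nitrogen does not by itself bring a number here. Pyridin-4-yl in place of benzyl gives a number no lower from compound 1 to compound 4 (the limit leaves the size open), and the steps between the limits themselves cannot be read. This change adds one more compound at the limit: the limit of > 50000 nM in this assay, at which 3 of the 4 values shown sit.

From the compounds shown here alone, how far the compounds at the limit lie beyond it stays open. Also open, going by these compounds, is whether a chain ending in an amine or a carboxylic acid on this nitrogen would give a number in this assay.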